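The source may report more compounds than this note shows. Statements on the series, on what has been measured and on what is new or still open speak of the compounds shown alone.

In a physicochemical assay for solubility, read by HPLC, measured as thermodynamic solubility, with a stated time of 4 h, at pH 6.8 (on this read-out lower numbers stand for lower solubility and higher numbers for higher solubility), compound 3 `Cn1c(COc2cccc(C(=O)O)c2)nc2ccc(Oc3ccccn3)cc21` gives 62 ug/mL, the highest of the three numbers measured; compound 1 `Cn1c(COc2cccc(C(=O)O)c2)nc2ccc(Oc3ccc(F)cc3)nc21` gives 11 ug/mL and compound 2 `Cc1cc(C)cc(Oc2ccc3nc(COc4cccc(C(=O)O)c4)n(C)c3n2)c1` gives 0.5 ug/mL. Compound 4 `Cc1cnc(Oc2ccc3nc(COc4cccc(C(=O)O)c4)n(C)c3c2)c(F)c1` differs from compound 3 by 3-fluoro-5-methylpyridin-2-yl in place of pyridin-2-yl on an oxygen on an aromatic ring. Among the compounds with values here, the one measured step that bears on this change is a 22-fold lower number from compound 1 to compound 2 (1.34 log units; beyond the scatter), where 3,5-dimethylphenyl replaced 4-fluorophenyl on an oxygen on an aromatic ring. The change to compound 4 also enlarges the ring on that oxygen, from pyridin-2-yl to 3-fluoro-5-methylpyridin-2-yl, so a step in the same downward direction is expected for compound 4, though a smaller one than that from compound 1 to compound 2. The expected step is a 5.2-fold lower number from compound 3 to compound 4 (0.71 log units; beyond the scatter). Compound 4 is therefore estimated at 12 ug/mL, with a range from 4 ug/mL to 35 ug/mL.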

Compound 4, solubility: 9.2 ug/mL
Beside the measured number, compound 4's estimate is 1.3-fold (0.12 log units) above it; low and high end bracket the measured number.
By their numbers in this assay, from the lowest: compound 2; then compounds 4 and 1 (each within the scatter of the next); then compound 3.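

In this assay, 3-fluoro-5-methylpyridin-2-yl in place of pyridin-2-yl gives a 6.7-fold lower number from compound 3 to compound 4 (0.83 log units; beyond the scatter), so a downward step at this position now appears on a pyridin-2-yl ring as well as on the substituted phenyl rings of the earlier pair. Fluorine and methyl enter together here, so this step belongs to the pair and cannot be divided between them. Nothing measured here explains the drop. On these data alone, it remains open whether 3-fluoropyridin-2-yl or 5-methylpyridin-2-yl alone would account for the step. As far as these compounds go, how an amine or a carboxylic acid on this ring would read also remains open.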